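Working notes on solubility in a shared-core series

A few compounds are considered here, and "the series" means these few. Any claim that something is new, unique, unknown or untested is made for them only; others in the source may bear on it.

compound 1 `COc1ccc(F)cc1CNCCCNc1ccnc2cc(Cc3cc(C)cc(C)c3)ccc12`: 4200 nM
compound 2 `COc1ccc(F)cc1CNCCCNc1ccnc2cc(Cc3ccc(F)cc3Cl)ccc12`: 4200 nM
compound 3 `COc1ccc(F)cc1CNCCCNc1ccnc2cc(Cc3ccc(C#N)cc3)ccc12`: 4200 nM

In a physicochemical assay for solubility, with a stated time of 18 h, at pH 7.4 (on this read-out lower numbers stand for lower solubility and higher numbers for higher solubility), compound 3 stands level with compounds 1 and 2; its nearest neighbour is compound 1 and its furthest compound 2, both within the scatter. The next compound, compound 4 `COc1ccc(F)cc1CNCCCNc1ccnc2cc(-c3ccc(C(F)(F)F)cc3)ccc12`, differs from compound 3 by 4-(trifluoromethyl)phenyl in place of 4-cyanobenzyl on an aromatic carbon.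

The measured steps all exchange one arene for another on a saturated chain carbon: no change at the digits printed from compound 1 to compound 2 (within the scatter), no change at the digits printed from compound 1 to compound 3 (within the scatter) and no change at the digits printed from compound 2 to compound 3 (within the scatter). None of them removes that saturated chain carbon or brings in a trifluoromethyl group, so they bear on the present step only loosely; they show the read-out to be flat across the three arenes tried.

For compound 4 a step of about a 1.4-fold lower number from compound 3 to compound 4 (0.15 log units; within the scatter) is therefore expected, a slight fall that may still fall inside the scatter. The expected value for compound 4 is 3000 nM, with a range from 1000 nM to 6000 nM.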

Compound 4, solubility: 32000 nM
Beside the measured number, compound 4's estimate is 11-fold (1.03 log units) below it; measured number above the stated range.
By their numbers in this assay, from the lowest: compounds 1, 2 and 3 (each within the scatter of the next); then compound 4.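

In this assay this position responds where exchanges of one arene for another on the saturated chain carbon did not: (a 7.6-fold higher number from compound 3 to compound 4 (0.88 log units; beyond the scatter)), (a 7.6-fold higher number from compound 2 to compound 4 (0.88 log units; beyond the scatter)) and (a 7.6-fold higher number from compound 1 to compound 4 (0.88 log units; beyond the scatter)). Each step removes a benzyl group and brings in 4-(trifluoromethyl)phenyl on the aromatic carbon, so the three benzyl compounds, level with one another, all part from compound 4 to the same extent. Nothing measured here accounts for the rise.

The loss of the saturated chain carbon and the arrival of trifluoromethyl come together in this change and cannot be told apart. Open too, going by these compounds, is how 4-cyanophenyl on the same aromatic carbon, or an amine there, would read.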